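A Phenyl Swap at a Carbonyl Carbon

The source may report more compounds than this note shows. Statements on the series, on what has been measured and on what is new or still open speak of the compounds shown alone.

For the measured compounds named here, only two compounds have been tested so far, and they differ in more than one place. In a functional assay on P388 cells (Mus musculus) (on this read-out higher numbers stand for weaker inhibition and lower numbers for stronger inhibition), compound 1 `O=C(/C=C/c1ccc(F)cc1)Oc1ccc(/C=C2\CCCCC2=O)cc1` gives > 50000 nM, which is a limit of the assay and not a number. Going by the values given here, compound 2 `Cc1ccc(/C=C/C(=O)Oc2ccc(/C=C3\CCCC(CN(C)C)C3=O)cc2)cc1` gives 1290 nM in this assay, and this is the only actual number available, so there is no series against which to rank it.

The next compound to be tested is compound 3 `CN(C)CC1CCC/C(=C\c2ccc(OC(=O)c3ccccc3)cc2)C1=O`. It carries phenyl in place of 2-(4-methylphenyl)ethenyl on a carbonyl carbon. Among the compounds with values here, no measured step between the two tested compounds isolates this kind of change, so the expectation is anchored on compound 2 at 1290 nM and carries wide uncertainty. A modest move towards weaker inhibition is expected, possibly no larger than the usual scatter, rather than a fall to the limit seen for compound 1. The expected change is a 1.7-fold higher number from compound 2 to compound 3 (0.23 log units; within the scatter). For compound 3 the estimated value is 2200 nM, with an expected range of 600 nM to 8000 nM.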

Compound 3, half-maximal inhibitory concentration: 180 nM
Estimate against measurement, compound 3: 12-fold (1.09 log units) above; measured number outside the range, below it.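

Replacing 2-(4-methylphenyl)ethenyl with phenyl on a carbonyl carbon gives, in this assay, a 7.2-fold lower number from compound 2 to compound 3 (0.86 log units; beyond the scatter). This is the only single-place step shown, and it reveals that inhibition in these cells does not depend on keeping the 2-(4-methylphenyl)ethenyl group at this position: phenyl, with fewer heavy atoms and no double bond outside the aromatic ring, goes with the lower number. The finding rests on this one pair, and it cannot yet be called a pattern for other compounds.

From the compounds shown here alone, both the double bond and the methyl group leave together in this step, so it remains open which of them matters, and it is equally open how a plain 2-phenylethenyl, a 4-methylphenyl, a methoxy-substituted phenyl or a short alkyl chain would behave on the same carbonyl carbon. Compound 1 differs from the other two in more than one place and stays outside this reading, its result being a limit and not a number in this assay: the limit of > 50000 nM in this assay, at which 1 of the 3 values shown sits.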